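Methoxy for methyl on the anilino ring: cytotoxicity note

A few compounds are considered here, and "the series" means these few. Any claim that something is new, unique, unknown or untested is made for them only; others in the source may bear on it.

Compound 1 `Clc1ccc2c(NCCCCNc3nccc(Nc4ccccc4)n3)ccnc2c1` and compound 2 `Cc1ccc(Nc2ccnc(NCCCCNc3ccnc4cc(Cl)ccc34)n2)cc1` share the same core and differ only on the anilino ring. In an ADME assay on Vero cells (Chlorocebus sabaeus) for cytotoxicity, read by neutral red uptake, with a stated time of 72 h (a higher number here means a weaker inhibitor, a lower number a stronger inhibitor), compound 1 gives 14300 nM. In this assay compound 2 gives 19300 nM. For the measured compounds named here, the single measured step, a 1.3-fold higher number from compound 1 to compound 2 (0.13 log units; within the scatter), is within the scatter, so compound 2 stands at one of two numbers that cannot be told apart; nothing separates it from compound 1 in this assay.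

Compound 3 `COc1ccc(Nc2ccnc(NCCCCNc3ccnc4cc(Cl)ccc34)n2)cc1` is the next member. Its difference from compound 2 is methoxy in place of methyl on an aromatic carbon. Going by the values given here, the only measured step that bears on this position is the one from compound 1 to compound 2, and that step stayed within the scatter. Among the compounds with values here, no measured pair shows what a methoxy group does on this ring, and no other change on the core has been tested, so the expectation rests on that one flat step.

The expected step of a 1.0-fold lower number from compound 2 to compound 3 (0.01 log units; within the scatter) is therefore none beyond the scatter. Compound 3 is estimated in this assay at 19000 nM, with a range from 8500 nM to 42000 nM.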

Compound 3, half-maximal inhibitory concentration: 11100 nM
Compound 3: the middle estimate sits 1.7-fold (0.23 log units) above what was measured; the range from low to high includes it.
By their numbers in this assay, from the lowest: compounds 3, 1 and 2 (each within the scatter of the next).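

Working notes on the anilino ring: in this assay the change from methyl to methoxy, on the aromatic carbon para to a large group, gives a 1.7-fold lower number from compound 2 to compound 3 (0.24 log units; within the scatter) and sets a second substituent against the earlier methyl. Read against the bare ring, the methoxy group gives a 1.3-fold lower number from compound 1 to compound 3 (0.11 log units; within the scatter) and so joins the methyl step as a further change that stays within the scatter, which means hydrogen, methyl and methoxy at this place cannot be told apart in this cytotoxicity read-out, even with the added oxygen, its one hydrogen-bond acceptor and the one extra heavy atom. No measurement bearing on why the three numbers fall so close together is in hand.

On these data alone, whether an amine or a carboxylic acid at this place, or a longer chain such as ethoxy in place of the methoxy group, would carry the number beyond the scatter stays open. The three compounds also leave open whether a change at another place on the anilino ring, or elsewhere on the shared core, would separate any compound from this group.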